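This account rests on a few compounds, and the source may have more. Where it says the series, first, only, none or still open, it means among the compounds named here.

Compound 1 `COc1ccc(-c2cc(/C=C/C(=O)c3ccc(OC)c(OC)c3)[nH]n2)cc1`: 1010 nM
Compound 2 `COc1cc(-c2cc(/C=C/C(=O)c3ccc(Cl)c(Cl)c3)[nH]n2)cc(OC)c1OC`: 2950 nM

In a functional assay on HCT-116 cells (Homo sapiens) for inhibition, read by sulforhodamine B assay, with a stated time of 48 h (on this read-out higher numbers stand for weaker inhibition of growth and lower numbers for stronger inhibition of growth), compound 2 gives the higher of the two numbers; compound 1 gives 1010 nM, a gap beyond the usual scatter. The two compounds differ in more than one place, so their values are only compared as they stand. Compound 3 `COc1cc(-c2cc(/C=C/C(=O)c3ccc(F)c(F)c3)[nH]n2)cc(OC)c1OC` differs from compound 2 in one place: 3,4-difluorophenyl in place of 3,4-dichlorophenyl on a carbonyl carbon. Among the measured compounds shown here, no measured step of this kind exists in this set, so only a modest step is expected, a 1.2-fold higher number from compound 2 to compound 3 (0.07 log units; within the scatter), with no firm direction. Compound 3 is estimated at 3500 nM, within 1500 nM to 9000 nM.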

Compound 3, concentration for 50% growth inhibition: 4000 nM
Compound 3: the middle estimate sits 1.1-fold (0.06 log units) below what was measured, within the range that was stated.
By their numbers in this assay, from the lowest: compound 1; then compounds 2 and 3 (each within the scatter of the next).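

In this assay, among the compounds shown here, 3,4-difluorophenyl in place of 3,4-dichlorophenyl on a carbonyl carbon gives a 1.4-fold higher number from compound 2 to compound 3 (0.13 log units; within the scatter) and so provides the first comparison in this set that differs in one place only. At this position, the two rings cannot be told apart on this read-out. Nothing measured here bears on this result. The compounds shown leave open how this read-out would respond to a phenyl ring carrying an amine or a carboxylic acid on that carbonyl carbon.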